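The source may hold more compounds than are shown below. What is called first, only, known or untested is meant among the compounds shown, and "the series" means these compounds.

Measured so far in an in vivo functional assay on the whole organism for inhibition, with Rattus norvegicus as the target; on this read-out higher numbers stand for an effect only at larger amounts of compound and lower numbers for an effect already at smaller amounts:
- compound 1 `CCCCc1nc(C)c(CC(=O)N(CC)CC)c(=O)n1Cc1ccc(-c2ccccc2-c2nnn[nH]2)cc1` gives 0.089 mg/kg
- compound 2 `CCCCc1nc(C)c(CC(=O)N2CCC[C@H]2C(=O)OC)c(=O)n1Cc1ccc(-c2ccccc2-c2nnn[nH]2)cc1` gives 0.043 mg/kg
- compound 3 `CCCCc1nc(C)c(CC(=O)N2CCN(C)CC2)c(=O)n1Cc1ccc(-c2ccccc2-c2nnn[nH]2)cc1` gives "not determined" (no result reported)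

On the two numbers available, compound 1 stands highest; the nearest entry is compound 2, with a 2.1-fold lower number from compound 1 to compound 2 (0.32 log units; beyond the scatter), a modest step that follows from 2-(methoxycarbonyl)pyrrolidin-1-yl in place of diethylamino on a carbonyl carbon. Compound 3 adds nothing to the comparison, as no number was obtained for it.

Compound 4 `CCCCc1nc(C)c(CCC(=O)N2CCCCC2)c(=O)n1Cc1ccc(-c2ccccc2-c2nnn[nH]2)cc1` differs from compound 1 as follows: ((piperidin-1-yl)carbonyl)methyl in place of diethylcarbamoyl on a saturated chain carbon bound to an aromatic carbon

Among the compounds with values here, only the step from compound 1 to compound 2 bears on this change, and only in part: it too exchanges the substituents on the amide nitrogen, and it moved the number down by a modest amount. The lengthening of the chain between the core and the carbonyl, from (diethylcarbamoyl)methyl to 2-((piperidin-1-yl)carbonyl)ethyl, has no measured counterpart among the compounds shown. The expectation for compound 4 is therefore a step no larger than the scatter, leaning slightly towards a lower number, and it is estimated as a 1.2-fold lower number from compound 1 to compound 4 (0.07 log units; within the scatter). Compound 4 is expected to give about 0.075 mg/kg, with a range from 0.025 mg/kg to 0.25 mg/kg.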

Compound 4, dose for half-maximal effect: 0.164 mg/kg
The estimate for compound 4 lay 2.2-fold (0.34 log units) below the measured number; the range from low to high includes it.
By their numbers in this assay, from the lowest: compound 2; then compounds 1 and 4 (each within the scatter of the next).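

In this assay, the change from (diethylcarbamoyl)methyl to 2-((piperidin-1-yl)carbonyl)ethyl gives a 1.8-fold higher number from compound 1 to compound 4 (0.27 log units; within the scatter), so this position accepts the longer chain together with the piperidine amide without a step that stands clear of the scatter. Set against the (2-(methoxycarbonyl)pyrrolidin-1-yl)carbonyl group, the same piperidine-bearing group gives a 3.8-fold higher number from compound 2 to compound 4 (0.58 log units; beyond the scatter), which leaves compound 2 with the lowest number of the three, its steps to both others lying beyond the scatter. Nothing at hand bears on the reason for these differences.

Compound 4 alters the chain and the amide nitrogen substituents together, so the shares of the two changes stay unseparated; a piperidine amide on the shorter chain, or a diethylamide on the ethyl chain, would divide them. Also open, from the compounds shown here alone, are whether the methyl ester of compound 2 matters, which a carboxylic acid or a primary amide at that carbon would test, and how a still longer chain or a basic amine such as the methylpiperazine of compound 3 would read, as compound 3 has no number.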